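The compounds below may be only part of what the source reports. "The series", "measured", "known", "first", "only" and "open" are said of these compounds alone.

Compound 1 `CC(=O)OC/C(=C\c1ccc(Cl)cc1Cl)C(=O)c1ccccc1`: 3500 nM
Compound 2 `CC(=O)OC/C(=C\c1ccc(Cl)cc1)C(=O)c1ccc(Cl)cc1`: 3400 nM

Both numbers come from a functional assay on SW1573 cells (Homo sapiens) for inhibition, read by sulforhodamine B assay, with a stated time of 48 h; on this read-out higher numbers stand for weaker inhibition of growth and lower numbers for stronger inhibition of growth. In this assay compound 1 gives 3500 nM and compound 2 gives 3400 nM. Compound 2 holds the lowest of the two numbers shown, but compound 1 sits within the scatter of it, so the two cannot be told apart.

Compound 3 `CC(=O)OC/C(=C\c1ccc(Cl)cc1Cl)C(=O)c1ccc(Cl)cc1` has not yet been measured in this assay. It differs from compound 2 by chloro in place of hydrogen on an aromatic carbon, which, seen one bond further out, turns a 4-chlorophenyl into a 2,4-dichlorophenyl. For the measured compounds named here, no measured pair shows this change on its own. Compounds 1 and 2 differ in two places and still give numbers within the scatter of each other, which gives no sign that adding or moving a chloro group shifts growth inhibition here. The step of a 1.1-fold lower number from compound 2 to compound 3 (0.03 log units; within the scatter) is therefore expected to stay within the scatter, in no particular direction. Compound 3 is estimated at 3200 nM, with a range from 1200 nM to 8500 nM.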

Compound 3, concentration for 50% growth inhibition: 3400 nM
Compound 3: the middle estimate sits 1.1-fold (0.03 log units) below what was measured; the measured number falls inside the stated range.
By their numbers in this assay, from the lowest: compounds 2, 3 and 1 (each within the scatter of the next).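

In this assay, chloro in place of hydrogen on an aromatic carbon, ortho to a large group and meta to a chloro group, can now be read on its own: turning a 4-chlorophenyl into a 2,4-dichlorophenyl gives no change at the digits printed from compound 2 to compound 3 (within the scatter) and so leaves growth inhibition where it was. The same kind of swap at another aromatic carbon gives a 1.0-fold lower number from compound 1 to compound 3 (0.01 log units; within the scatter) and likewise shows no readable shift, so a third chloro is tolerated at either place. Nothing measured here offers an explanation for this flat result.

As far as these compounds go, what stays open is whether a group other than chloro at this place, such as an amine or a carboxylic acid, would move the number. A larger group there, such as a longer chain, might also behave differently from chloro.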